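The source may report more compounds than this note shows. Statements on the series, on what has been measured and on what is new or still open speak of the compounds shown alone.

Measured compounds:
compound 1, `COc1ccc2c(C(=O)Nc3cc(F)cc(F)c3)cc(=O)[nH]c2n1`: > 20000 nM
compound 2, `COc1ccc(-c2ccc3c(C(=O)Nc4cccc(F)c4)cc(=O)[nH]c3c2)cc1`: 18000 nM

In a functional assay on KYSE-410 cells (Homo sapiens) for antiproliferative activity, read by MTT assay, with a stated time of 72 h (on this read-out lower numbers stand for stronger inhibition and higher numbers for weaker inhibition), compound 2 gives 18000 nM, and this is the only number recorded among the compounds shown. For compound 1 the result is a limit of the assay, > 20000 nM, so no number is known for it. That limit, (the limit of > 20000 nM in this assay, at which 1 of the 2 values shown sits), marks the edge of what this assay reports. For the measured compounds named here, compound 2 therefore stands as the sole measured value, and it lies in a weak range. Compound 3, `C=Cc1ccc2c(C(=O)Nc3cccc(F)c3)cc(=O)[nH]c2c1`, shares the core of compound 2 and differs from it in one place: vinyl in place of 4-methoxyphenyl on an aromatic carbon. No measured step of this kind exists among the compounds shown, so no direction can be read from the data; the expected step in this assay is none beyond the scatter, with a wide spread and a real chance of a limit rather than a number. Compound 3 is expected at about 25000 nM in this assay, estimated between 8000 nM and 60000 nM. This estimate means a step of a 1.4-fold higher number from compound 2 to compound 3 (0.14 log units; within the scatter).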

Compound 3, half-maximal inhibitory concentration: 13600 nM
Compound 3: the middle estimate sits 1.8-fold (0.26 log units) above what was measured; low and high end bracket the measured number.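

Putting vinyl in place of 4-methoxyphenyl on this aromatic carbon gives a 1.3-fold lower number from compound 2 to compound 3 (0.12 log units; within the scatter) in this assay. For the compounds shown here, this is the first comparison at this position, and it shows that losing the whole aromatic ring of the 4-methoxyphenyl group leaves two compounds that this read-out cannot tell apart, with neither giving strong inhibition. Compound 1 remains a limit of the assay rather than a number, so it adds no step, and the read-out ends not far from the numbers of the other two compounds: the limit of > 20000 nM in this assay, at which 1 of the 3 values shown sits.

On these data alone, it remains open whether an amine, a carboxylic acid or a longer carbon chain on this aromatic carbon would give a clearly lower number. Also open, as far as these compounds go, is whether any group at this position can move the read-out beyond the scatter.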